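Trifluoromethyl for Fluoro on a Pyridyl Ether Core

The source may hold more compounds than are shown below. What is called first, only, known or untested is meant among the compounds shown, and "the series" means these compounds.

Measured so far:
- compound 1 `Brc1ccc(OC[C@@H]2CCN2)cn1`: 0.021 nM
- compound 2 `Cc1ccc(OC[C@@H]2CCN2)cn1`: 0.057 nM
- compound 3 `Fc1cncc(OC[C@@H]2CCN2)c1`: 0.076 nM

Of the compounds shown here, three sharing one core have been tested in an assay on brain for binding affinity to Neuronal acetylcholine receptor; alpha4/beta2 (Rattus norvegicus), read by radioligand binding; a lower number here means a stronger inhibitor, a higher number a weaker inhibitor. Compound 1 gives 0.021 nM, compound 2 gives 0.057 nM, and compound 3 gives 0.076 nM. Compound 3 therefore stands at the highest number of the three; its gap to compound 2 is within the scatter, while its gap to compound 1 is beyond it. The only single-point step among these, the change of bromo to methyl, gave a 2.7-fold higher number from compound 1 to compound 2 (0.43 log units; beyond the scatter), a modest shift.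

Compound 4 `FC(F)(F)c1cncc(OC[C@@H]2CCN2)c1` has not yet been measured in this assay. It differs from compound 3 in one place: trifluoromethyl in place of fluoro on an aromatic carbon. For the measured compounds named here, no measured step exchanges fluoro for trifluoromethyl, so the one step that exists, from compound 1 to compound 2, bears on it only loosely, showing that a swap of a small group at this kind of position moved the number modestly. A step of similar, modest size is expected here, most likely towards a higher number, though a result within the scatter would not surprise. The estimate for compound 4 is 0.2 nM, with a range from 0.05 nM to 0.8 nM, which corresponds to an expected step of a 2.6-fold higher number from compound 3 to compound 4 (0.42 log units; beyond the scatter).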

Compound 4, inhibition constant: 0.49 nM
For compound 4 the middle estimate is 2.5-fold (0.39 log units) below the measured one; measured number inside the range.
By their numbers in this assay, from the lowest: compound 1; then compounds 2 and 3 (each within the scatter of the next); then compound 4.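

Swapping fluoro for trifluoromethyl, on an aromatic carbon two atoms from the ring nitrogen, gives a 6.4-fold higher number from compound 3 to compound 4 (0.81 log units; beyond the scatter) in this assay and shows that this position responds to the change: the earlier bromo-to-methyl step involved neither of these groups and could not show this. Even so, compound 4 keeps a small number, 0.49 nM in this assay, so replacing a substituent of 1 heavy atom with one of 4 heavy atoms lowers the binding without abolishing it. Nothing among the available data explains why the number rises, so the step stands as an observation and not as an explained effect.

A single pair cannot tell whether the rise follows the number of heavy atoms in the group or depends on what those atoms are. A chloro group, a methoxy group, a nitrile or an amine on the same aromatic carbon of the shared core would help to separate these possibilities, and would show whether any group here gives a lower number than fluoro.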